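Swapping the Chain-End Ring on a Second Core

The compounds below may be only part of what the source reports. "The series", "measured", "known", "first", "only" and "open" are said of these compounds alone.

Compound 1 `Clc1ccc2c(NCCCN3CCCCC3)ccnc2c1` carries a chloro on its core and a piperidin-1-yl at the end of a saturated chain that starts at a nitrogen on an aromatic ring. In a functional assay on MCF7 cells (Homo sapiens) for antiproliferative activity, read by sulforhodamine B assay, with a stated time of 48 h (a higher number here means a weaker inhibitor of growth, a lower number a stronger inhibitor of growth), compound 1 gives 17700 nM. Compound 2 `CN1CCN(CCCNc2ccnc3cc(Cl)ccc23)CC1` differs from it by 4-methylpiperazin-1-yl in place of piperidin-1-yl on a saturated chain carbon, three bonds along the chain from a nitrogen on an aromatic ring, and in this assay compound 2 gives 17100 nM, which amounts to a 1.0-fold lower number from compound 1 to compound 2 (0.01 log units; within the scatter). Compound 3 `FC(F)(F)c1ccc2c(NCCCN3CCCCC3)ccnc2c1` keeps the piperidin-1-yl, but its core differs from that of compound 1 by trifluoromethyl in place of chloro on an aromatic carbon; in this assay compound 3 gives 32600 nM, a step of a 1.8-fold higher number from compound 1 to compound 3 (0.27 log units; within the scatter). All three measured numbers therefore lie within the usual scatter of one another, and none of them can be called stronger or weaker than the rest.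

Compound 4 `CN1CCN(CCCNc2ccnc3cc(C(F)(F)F)ccc23)CC1` has not yet been measured. It differs from compound 3 by 4-methylpiperazin-1-yl in place of piperidin-1-yl on a saturated chain carbon, three bonds along the chain from a nitrogen on an aromatic ring. This is the same change, made at the same place, that separates compound 1 from compound 2, and on that core it produced a 1.0-fold lower number from compound 1 to compound 2 (0.01 log units; within the scatter). Because the earlier instance gave a 1.0-fold lower number from compound 1 to compound 2 (0.01 log units; within the scatter), a similarly small step is expected here, namely a 1.1-fold lower number from compound 3 to compound 4 (0.02 log units; within the scatter). Compound 4 is thus estimated to give about 31000 nM in this assay, with a likely range from 15000 nM to 65000 nM. This rests on a single earlier example of the change, so the expectation is loose.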

Compound 4, concentration for 50% growth inhibition: 30800 nM
The estimate for compound 4 lay 1.0-fold (0.00 log units) above the measured number; low and high end bracket the measured number.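

In this assay, 4-methylpiperazin-1-yl in place of piperidin-1-yl on the core carrying trifluoromethyl gives a 1.1-fold lower number from compound 3 to compound 4 (0.02 log units; within the scatter), and this step agrees with the one seen on the core carrying chloro: the same change on two cores in this assay, a 1.0-fold lower number (0.01 log units; within the scatter) from compound 1 to compound 2 and a 1.1-fold lower number (0.02 log units; within the scatter) from compound 3 to compound 4, 1.0-fold (0.01 log units) apart, within the scatter of two such steps. The other change, trifluoromethyl in place of chloro, can now also be read with 4-methylpiperazin-1-yl at the chain end, where it gives a 1.8-fold higher number from compound 2 to compound 4 (0.26 log units; within the scatter), and it too agrees with its earlier instance: the same change on two cores in this assay, a 1.8-fold higher number (0.27 log units; within the scatter) from compound 1 to compound 3 and a 1.8-fold higher number (0.26 log units; within the scatter) from compound 2 to compound 4, 1.0-fold (0.01 log units) apart, within the scatter of two such steps. Together these four compounds show that each change carries over between these two cores with the same outcome, a step within the scatter, but they do not show that the groups are interchangeable in general, since the agreement rests on one pair of steps per change in a single assay and concerns only steps too small to read.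

The compounds shown leave open whether any change at these two places can give a step beyond the scatter, for instance a morpholine or a primary amine at the chain end, a longer chain, or a methoxy or nitrile in place of chloro. They also leave open whether the same agreement between cores would hold for a larger step.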